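Octyl in Place of Vinyl: Expecting Compound 4

The source may hold more compounds than are shown below. What is called first, only, known or untested is meant among the compounds shown, and "the series" means these compounds.

Measured compounds:
compound 1, `CCCCCCOc1ccc2c(=O)c(-c3ccc(O)cc3)coc2c1`, gives 1500 nM in an assay (Cricetulus griseus) for inhibition of aldehyde dehydrogenase, mitochondrial (Homo sapiens); a lower number here means a stronger inhibitor, a higher number a weaker inhibitor
compound 2, `O=C(O)CCCCOc1ccc2c(=O)c(-c3ccc(O)cc3)coc2c1`, gives 100 nM in this assay
compound 3, `C=CCCCCOc1ccc2c(=O)c(-c3ccc(O)cc3)coc2c1`, gives 150 nM in this assay

Compound 3 stands second highest of the three numbers in this assay. Its nearest neighbour is compound 2, where a 1.5-fold higher number from compound 2 to compound 3 (0.18 log units; within the scatter), so the two cannot be told apart. Its furthest is compound 1, where a 10-fold lower number from compound 1 to compound 3 (1.00 log units; beyond the scatter).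

Compound 4, `CCCCCCCCCCCCOc1ccc2c(=O)c(-c3ccc(O)cc3)coc2c1`, differs from compound 3 in one place: octyl in place of vinyl on a saturated chain carbon, four bonds along the chain from an oxygen on an aromatic ring. The double bond outside aromatic rings of compound 3 is gone, and the chain is much longer.

Within the data shown here, two measured steps bear on this. The step from compound 1 to compound 3, a 10-fold lower number from compound 1 to compound 3 (1.00 log units; beyond the scatter), is the closest reverse of the present change, since both concern a saturated chain carbon four bonds along the chain from an oxygen on an aromatic ring and both swap the terminal group for one with or without the double bond. The step of a 15-fold lower number from compound 1 to compound 2 (1.18 log units; beyond the scatter) shows the same position moving the number strongly in the other direction when a carboxy enters. Among the measured compounds shown here, no measured compound carries a chain as long as octyl at this place, so its effect beyond removing the double bond is unknown.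

For compound 4 the expected step is therefore a 10-fold higher number from compound 3 to compound 4 (1.00 log units; beyond the scatter) in this assay, back toward compound 1. Compound 4 is estimated at 1500 nM, with a range from 300 nM to 8000 nM.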

Compound 4, half-maximal inhibitory concentration: > 9000 nM
Compound 4 gave a limit, no number; the forecaster's own chance of this, stated with the estimate: 15%; middle value at least 6.0-fold (0.77 log units) away from the limit.
By their numbers in this assay, from the lowest: compounds 2 and 3 (each within the scatter of the next); then compound 1. At a limit, above all of these: compound 4.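

In this assay compound 4 stands only at a limit of the assay and not at a number: the limit of > 9000 nM in this assay, at which 1 of the 4 values shown sits.

Hexyl in place of hydrogen on a saturated chain carbon, six bonds along the chain from an oxygen on an aromatic ring, gives an at least 6.0-fold higher number from compound 1 to compound 4 (0.77 log units; beyond the scatter), which shows that the length of a saturated chain at this place matters in itself, something the earlier compounds could not show. Octyl in place of vinyl gives an at least 60-fold higher number from compound 3 to compound 4 (1.77 log units; beyond the scatter) and octyl in place of carboxy gives an at least 90-fold higher number from compound 2 to compound 4 (1.95 log units; beyond the scatter), so the present change does more than undo a 10-fold lower number from compound 1 to compound 3 (1.00 log units; beyond the scatter).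

The compounds shown leave open whether a chain of a length lying between those of compound 1 and compound 4 would give a number between theirs, and how far past its limit compound 4 truly lies. Also open, from the compounds shown here alone, is whether a carboxylic acid or an amine at the end of the longer chain would bring the number back toward those of compound 2 and compound 3.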